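The source may report more compounds than this note shows. Statements on the series, on what has been measured and on what is new or still open speak of the compounds shown alone.

Measured so far:
Compound 1 `Oc1cccc(-c2cc(-c3ccsc3)cc(-c3ccccc3O)n2)c1` gives > 50000 nM in a functional assay on HeLa cells (Homo sapiens) for cytotoxicity, read by CCK-8 assay (a higher number here means a weaker inhibitor, a lower number a stronger inhibitor), which is a limit of the assay.
Compound 2 `Oc1cccc(-c2cc(-c3ccoc3)cc(-c3ccccc3O)n2)c1` gives > 50000 nM in this assay, also a limit.
Compound 3 `Oc1cccc(-c2cc(-c3ccoc3)cc(-c3cccc(O)c3)n2)c1` gives 4630 nM in this assay.

Compound 2 thus stands at the limit, as does compound 1, and only compound 3 gives a number. Compound 4 `Oc1cccc(-c2cc(-c3ccccn3)cc(-c3ccccc3O)n2)c1` differs from compound 2 by pyridin-2-yl in place of furan-3-yl on an aromatic carbon. For the measured compounds named here, the one step at this position, a step that the two limits leave unreadable from compound 1 to compound 2, is unreadable, so nothing is known about exchanging the aryl group there. Going by the values given here, the only readable step, an at least 10-fold lower number from compound 2 to compound 3 (1.03 log units; beyond the scatter), concerns the 2-hydroxyphenyl group, which compound 4 keeps. Given (the limit of > 50000 nM in this assay, at which 2 of the 3 values shown sit), no step beyond the scatter is expected from compound 2 to compound 4. The expected step is a step that the limit leaves unreadable from compound 2 to compound 4. Compound 4 is therefore estimated at 60000 nM, range 15000 nM to 200000 nM, most likely reported again only as a limit.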

Compound 4, half-maximal inhibitory concentration: 2020 nM
Beside the measured number, compound 4's estimate is 30-fold (1.47 log units) above it; measured number below the stated range.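

In this assay, the aryl position opposite the ring nitrogen proves able to move the read-out: pyridin-2-yl in place of furan-3-yl gives an at least 24-fold lower number from compound 2 to compound 4 (1.39 log units; beyond the scatter), and pyridin-2-yl in place of thiophen-3-yl gives an at least 24-fold lower number from compound 1 to compound 4 (1.39 log units; beyond the scatter). The 2-hydroxyphenyl group, kept in compound 4, therefore does not by itself hold a compound at the limit. Both step sizes are lower bounds only: the limit of > 50000 nM in this assay, at which 2 of the 4 values shown sit.

From the compounds shown here alone, whether the step follows the six-membered ring or the ring nitrogen stays open, as a plain phenyl group here would test. Also open, going by these compounds, is how an amine or a carboxylic acid at this position would read.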